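Swapping tert-butoxycarbonyl for cyano on a growth inhibitor

The source may report more compounds than this note shows. Statements on the series, on what has been measured and on what is new or still open speak of the compounds shown alone.

Of the compounds shown here, two sharing one core have been measured so far. In a functional assay on Hs 683 cells (Homo sapiens) for inhibition, read by MTT assay, with a stated time of 72 h (on this read-out higher numbers stand for weaker inhibition of growth and lower numbers for stronger inhibition of growth), compound 1 `CC1(C)CCC[C@]2(C)[C@@H](C=O)C(C=O)=CC[C@@H]12` gives 95000 nM and compound 2 `CC(C)(C)OC(=O)/C=C/C1=CC[C@H]2C(C)(C)CCC[C@]2(C)[C@H]1C=O` gives 29000 nM (the lower number of the two, with a gap beyond the usual scatter). Compound 2 therefore stands as the stronger inhibitor of growth. The untested compound 3 `CC1(C)CCC[C@]2(C)[C@@H](C=O)C(/C=C/C#N)=CC[C@@H]12` differs from compound 2 in one place (cyano in place of tert-butoxycarbonyl on a double-bonded chain carbon bound to a double-bonded chain carbon): cyano in place of tert-butoxycarbonyl on a double-bonded chain carbon bound to a double-bonded chain carbon. For the measured compounds named here, no measured pair differs in one place alone, so the data offer no guide to this swap, and the best anchor is compound 2 at 29000 nM in this assay as the starting point. The expected step of a 1.2-fold lower number from compound 2 to compound 3 (0.06 log units; within the scatter) is none beyond the scatter, with no firm direction. For compound 3 the estimate is 25000 nM with an expected range of 8000 nM to 70000 nM as its bounds.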

Compound 3, concentration for 50% growth inhibition: 28000 nM
For compound 3 the middle estimate is 1.1-fold (0.05 log units) below the measured one; the measured number falls inside the stated range.
By their numbers in this assay, from the lowest: compounds 3 and 2 (each within the scatter of the next); then compound 1.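

Replacing tert-butoxycarbonyl, with 7 heavy atoms, by cyano, with 2, on this double-bonded chain carbon gives a 1.0-fold lower number from compound 2 to compound 3 (0.02 log units; within the scatter) in this assay, so compound 2 and compound 3 cannot be told apart and the chain end accepts either group in this read-out. For the compounds shown here, the new compound also gives the first single-place comparison at the double-bonded ring carbon: 2-cyanoethenyl in place of formyl gives a 3.4-fold lower number from compound 1 to compound 3 (0.53 log units; beyond the scatter), a modest step. No supporting data explain either result.

These compounds leave open whether the chain end matters at all, since only two groups have been compared there, and a carboxylic acid or an amine could show whether other groups read the same. As far as these compounds go, whether the chain itself is needed, or a longer chain would give a larger step, also remains unknown.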